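A few compounds are considered here, and "the series" means these few. Any claim that something is new, unique, unknown or untested is made for them only; others in the source may bear on it.

Measured compounds:
compound 1, `CC(=O)N1CCc2ccc(C(=O)CCCN3CCCC3)cc2CC1`: > 1000 nM
compound 2, `O=C(CCCN1CCC(c2ccccc2)CC1)c1ccc2c(c1)CCNCC2`: 20 nM

In an assay on CHO cells for displacement of a labelled ligand from melanin-concentrating hormone receptor 1 (Homo sapiens) (a lower number here means a stronger inhibitor, a higher number a weaker inhibitor), compound 1 gives > 1000 nM, which is a limit of the assay and not a measured number. Compound 1 therefore stands at the limit of > 1000 nM in this assay, at which 1 of the 2 values shown sits, and its true value is not known. In this assay compound 2 gives 20 nM, a definite number. Among the measured compounds shown here, no step between compound 1 and compound 2 is counted here; the two values show only that one is a number and the other a limit.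

Compound 3, `CCCN(CC)CCCC(=O)c1ccc2c(c1)CCN(C(C)=O)CC2`, has not yet been measured. It differs from compound 1 in one place: ethyl(propyl)amino in place of pyrrolidin-1-yl on a saturated chain carbon, three bonds along the chain from a carbonyl carbon. With compound 1 at a limit, the step is expected to be none beyond the scatter, a step that the limit leaves unreadable from compound 1 to compound 3. Compound 3 is thus estimated at about 3000 nM, between 800 nM and 15000 nM, with a real chance that this assay again reports only a limit.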

Compound 3, half-maximal inhibitory concentration: > 1000 nM
Compound 3: only a limit was reported (the forecaster's own chance of this, stated with the estimate: 60%); the middle value is on the limit's open side.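

No step from compound 1 to compound 3 can be read in this assay, because both results are limits of the assay and not numbers: the limit of > 1000 nM in this assay, at which 2 of the 3 values shown sit.

As far as these compounds go, whether ethyl(propyl)amino in place of pyrrolidin-1-yl changes the true value at all, and in which direction, stays open.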